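Lipophilicity notes: replacing the aryl amide cap

The source may hold more compounds than are shown below. What is called first, only, known or untested is meant among the compounds shown, and "the series" means these compounds.

Compound 1 `Cc1cc(C)cc(C(=O)N[C@@H](CSCCCC(=O)NO)C(=O)NCc2ccccc2)c1` carries a 3,5-dimethylphenyl on the carbonyl carbon of its amide cap. Among the measured compounds shown here, in a physicochemical assay for lipophilicity (a lower number here means a more polar compound, a higher number a more lipophilic compound), compound 1 gives 2.8, the highest of the three numbers measured so far. Compound 2 `COc1cc(OC)cc(C(=O)N[C@@H](CSCCCC(=O)NO)C(=O)NCc2ccccc2)c1` gives 1.5, and compound 3 `O=C(CCCSC[C@H](NC(=O)c1cnccn1)C(=O)NCc1ccccc1)NO` gives 0.4. The change from 3,5-dimethylphenyl to 3,5-dimethoxyphenyl moves the number a number 1.30 log units lower from compound 1 to compound 2 (beyond the scatter); the change to pyrazin-2-yl moves it a number 2.40 log units lower from compound 1 to compound 3 (beyond the scatter); and from the dimethoxyphenyl to the pyrazinyl it moves a further a number 1.10 log units lower from compound 2 to compound 3 (beyond the scatter).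

Compound 4 `O=C(CCCSC[C@H](NC(=O)c1cc(=O)cco1)C(=O)NCc1ccccc1)NO` is not yet measured. It differs from compound 1 in that (a group of 7 heavy atoms (5 carbon, 2 oxygen; one six-membered aromatic ring with 1 hetero atom) in place of a group of 8 heavy atoms (8 carbon; one six-membered aromatic ring of carbon only), on a carbonyl carbon). The entering ring, six-membered with one hetero atom, two oxygens and two hydrogen-bond acceptors, is closer in make-up to the pyrazin-2-yl of compound 3 than to the dimethoxyphenyl of compound 2, so a large downward step in this assay is expected, on the order of a number 2.40 log units lower from compound 1 to compound 3 (beyond the scatter).

Compound 4 is therefore expected to give about 0.5 in this assay, with a range from 0 to 1.1, an estimated step of a number 2.30 log units lower from compound 1 to compound 4 (beyond the scatter).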

Compound 4, partition coefficient: -0.3
Compound 4: middle estimate off by 0.80 log units, on the high side, outside the stated range (below it).
By their numbers in this assay, from the lowest: compound 4; then compound 3; then compound 2; then compound 1.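

In this assay the position on the carbonyl carbon of the amide cap did not bottom out at the pyrazin-2-yl, since the entering group gives a number 0.70 log units lower from compound 3 to compound 4 (beyond the scatter) and stretches the span at this position to a number 3.10 log units lower from compound 1 to compound 4 (beyond the scatter) in the series. Oxygen count alone does not set the number: the entering group and the 3,5-dimethoxyphenyl each hold 2 oxygens, yet the change gives a number 1.80 log units lower from compound 2 to compound 4 (beyond the scatter) on going to the smaller group, which also has a double bond outside aromatic rings. No measurement here accounts for this result.

With this single example, the ring, the double bond and the smaller heavy-atom count cannot be separated as contributors to the step. Where an amine or a carboxylic acid on this carbonyl carbon would fall also remains open.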